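A few compounds are considered here, and "the series" means these few. Any claim that something is new, unique, unknown or untested is made for them only; others in the source may bear on it.

The study gathers a small set of compounds built on one shared core and tested in a functional assay on MCF7 cells (Homo sapiens) for cytotoxicity, read by MTT assay, with a stated time of 4 days; a lower number here means a stronger inhibitor, a higher number a weaker inhibitor. Compound 1 `C=C1C(=O)[C@]23C[C@@]1(O)CC[C@H]2c1ccc(O)c(C)c1[C@@H]3Cn1cc(-c2ccccc2)nn1` carries a plain phenyl group on its triazole and gives 1740 nM in this assay. Compound 2 `C=C1C[C@]23C[C@@]1(O)CC[C@@H]2c1cccc(C)c1[C@@H]3Cn1cc(-c2ccc(OC)cc2)nn1` bears a 4-methoxyphenyl group instead, and its core lacks the phenol of compound 1. For compound 2 the assay reports only a limit, > 20000 nM, not a number. Compound 3 `C=C1C[C@]23C[C@@]1(O)CC[C@H]2c1ccc(O)c(C)c1[C@@H]3Cn1cc(-c2ccc(Br)cc2)nn1` keeps the phenol of compound 1 but places a bromo on the aryl ring. For compound 3 the assay likewise returns a limit, > 20000 nM. Thus compound 2 stands at the weak end of what has been measured, sitting at the limit of > 20000 nM in this assay, at which 2 of the 3 values shown sit.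

For the measured compounds named here, the step under consideration leads from compound 2 to compound 4 `C=C1C[C@]23C[C@@]1(O)CC[C@@H]2c1cccc(C)c1[C@@H]3Cn1cc(-c2ccc(Br)cc2)nn1`, in which a bromo in place of methoxy on an aromatic carbon is the only change: bromo in place of methoxy on an aromatic carbon. Going by the values given here, no step between measured compounds is available to size this change directly. Since compound 2 already sits at a limit, and compound 3, the other bromo-bearing compound, also sits at a limit with > 20000 nM, the step from compound 2 to compound 4 is expected to be none beyond the scatter, most likely leaving compound 4 at a limit as well, with a step that the limit leaves unreadable from compound 2 to compound 4. Compound 4 is accordingly estimated at 25000 nM, within a range from 8000 nM to 60000 nM.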

Compound 4, half-maximal inhibitory concentration: > 20000 nM
Compound 4: a limit, no number; the forecaster's own chance of this, stated with the estimate: 75%; the middle value is on the limit's open side.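

In this assay compound 4 gives only a limit, > 20000 nM, not a number. Compound 2 also stands at a limit, so no step can be read between compound 2 and compound 4. The compounds shown leave open what bromo in place of methoxy does in this assay, where only compound 1 has a measured number.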